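The source may report more compounds than this note shows. Statements on the series, on what has been measured and on what is new or still open speak of the compounds shown alone.

Measured in an in vitro ADME assay on microsomes from liver (Homo sapiens) for metabolic stability; on this read-out lower numbers stand for slow clearance and higher numbers for fast clearance:
- compound 1 `O=C(COCc1ccccc1)N1CCN(c2ccc(F)cc2)CC1`: 110 mL.min-1.g-1
- compound 2 `O=C(COCc1ccncc1)N1CCC(c2ccc(F)cc2Cl)CC1`: 56 mL.min-1.g-1

For the measured compounds named here, compound 2, at 56 mL.min-1.g-1, lies within the usual scatter of compound 1, at 110 mL.min-1.g-1, the only other measured compound. The two values therefore do not separate these compounds.

Compound 3 `O=C(COCc1ccncc1)N1CCC(c2ccc(Cl)cc2Cl)CC1` differs from compound 2 in one place: chloro in place of fluoro on an aromatic carbon. This is chloro in place of fluoro on an aromatic carbon, meta to a chloro group and para to a large group, so that 2-chloro-4-fluorophenyl becomes 2,4-dichlorophenyl.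

Going by the values given here, no measured pair shows this change, so the data give no direct guide to its size in this assay. The expectation starts from compound 2 at 56 mL.min-1.g-1 and allows for a small move toward higher numbers, with no shift beyond the scatter as the likeliest outcome. The estimate means a 1.3-fold higher number from compound 2 to compound 3 (0.13 log units; within the scatter), which is expected to stay within the scatter. For compound 3 the estimated value is 75 mL.min-1.g-1, with an expected range of 35 mL.min-1.g-1 to 150 mL.min-1.g-1.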

Compound 3, intrinsic clearance in microsomes: 96 mL.min-1.g-1
Compound 3: the middle estimate sits 1.3-fold (0.11 log units) below what was measured, within the range that was stated.
By their numbers in this assay, from the lowest: compounds 2, 3 and 1 (each within the scatter of the next).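

In this assay, chloro in place of fluoro on an aromatic carbon, meta to a chloro group and para to a large group, gives a 1.7-fold higher number from compound 2 to compound 3 (0.23 log units; within the scatter). For the compounds shown here, this is the only step that isolates a single place, and it shows that 2-chloro-4-fluorophenyl and 2,4-dichlorophenyl are not separated on this read-out, so this position takes either chloro or fluoro without a difference that stands beyond the scatter. The data offer no measured basis for explaining the step, and no cause can be assigned to it.

On these data alone, whether this position responds to anything other than an exchange of one halogen for another remains open, since a single pair gives no guide to how an amine, a carboxylic acid or a methoxy group would read there. Going by these compounds alone, also open is whether the same exchange would read alike on a different core, such as the core of compound 1, for which no step of this kind is available.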